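Moving a Thiophene Attachment Point in a Growth Inhibitor

The source may report more compounds than this note shows. Statements on the series, on what has been measured and on what is new or still open speak of the compounds shown alone.

Compound 1 `Cc1cn2c(/C=N/Nc3ccccn3)c(-c3ccc(Cl)c([N+](=O)[O-])c3)nc2s1`: 16600 nM
Compound 2 `Cc1cn2c(/C=N/NC(=N)N)c(-c3ccsc3)nc2s1`: 7760 nM
Compound 3 `N=C(N)N/N=C/c1c(-c2ccsc2)nc2sccn12`: 6920 nM

In a functional assay on cells (Leukemia cell, Homo sapiens) for inhibition (a higher number here means a weaker inhibitor of growth, a lower number a stronger inhibitor of growth), compound 3 gives 6920 nM. Compound 2, at 7760 nM, lies within the scatter of it, so these two cannot be ranked. Compound 1 gives 16600 nM, a higher number than compound 3, and the gap between them lies beyond the scatter.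

The next compound to consider is compound 4 `N=C(N)N/N=C/c1c(-c2cccs2)nc2sccn12`. It keeps the same atoms as compound 3 but joins them differently, with thiophen-2-yl in place of thiophen-3-yl on an aromatic carbon.

Only one measured step connects two of these compounds: a 1.1-fold lower number from compound 2 to compound 3 (0.05 log units; within the scatter). It shows that hydrogen in place of methyl made no change that can be told from the scatter, but that is a different edit at a different place. Within the data shown here, no measured step shows what exchanging these two thiophene attachments does, so the data give no direction, and only a small change is assumed.

For this exchange, the expected result is a 1.1-fold lower number from compound 3 to compound 4 (0.03 log units; within the scatter), with no shift beyond the scatter anticipated. The estimated value for compound 4 is 6500 nM, with an expected range from 2500 nM to 17000 nM.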

Compound 4, concentration for 50% growth inhibition: 6760 nM
The estimate for compound 4 lay 1.0-fold (0.02 log units) below the measured number, within the range that was stated.
By their numbers in this assay, from the lowest: compounds 4, 3 and 2 (each within the scatter of the next); then compound 1.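

In this assay, exchanging thiophen-3-yl for thiophen-2-yl gives a 1.0-fold lower number from compound 3 to compound 4 (0.01 log units; within the scatter), so the two attachments cannot be told apart at this position, on an aromatic carbon next to the ring nitrogen. Among these compounds, the only earlier measured step concerned hydrogen in place of methyl at a different place, so this is the first direct reading at the position that carries the thiophene. It shows that, in this pair, joining the same five-membered ring through a different carbon leaves no difference that can be separated from the scatter of repeated measurements. No measurement is available here that would explain why the two compounds read alike.

On these data alone, the result covers one exchange on the core without the methyl group, so it remains open whether the same exchange would read alike on the methyl-bearing core of compound 2. It also leaves open what this position would accept if the thiophene gave way to a different group, such as a furan, an unsubstituted phenyl ring or a short alkyl chain.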